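Swapping an aromatic ring for a saturated one on a shared chain

The compounds below may be only part of what the source reports. "The series", "measured", "known", "first", "only" and "open" are said of these compounds alone.

Compound 1 `COc1ccc(C(=O)/C(=C/c2ccc(Cl)cc2Cl)CC(C)OC(C)=O)cc1` gives 36800 nM in a functional assay on NB-4 cells (Homo sapiens) for inhibition, read by XTT assay, with a stated time of 48 h; on this read-out lower numbers stand for stronger inhibition and higher numbers for weaker inhibition.
Compound 2 `COc1ccc(C(=O)/C(=C/C2CCCCC2)CC(C)OC(C)=O)cc1` gives 33400 nM in this assay.
Compound 3 `COc1ccc(C(=O)/C(=C/c2ccc(Cl)cc2Cl)CN(C)C(=O)c2ccccc2)cc1` gives 24000 nM in this assay.

All three share a core and differ in two places. Compound 1 and compound 2 differ by cyclohexyl in place of 2,4-dichlorophenyl on a double-bonded chain carbon bound to a double-bonded chain carbon, and that step is a 1.1-fold lower number from compound 1 to compound 2 (0.04 log units; within the scatter). Compound 1 and compound 3 differ by benzoyl(methyl)amino in place of 1-acetoxyethyl on a saturated chain carbon bound to a double-bonded chain carbon, and that step is a 1.5-fold lower number from compound 1 to compound 3 (0.19 log units; within the scatter). Compound 2 and compound 3 show values that lie within the scatter of each other.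

Compound 4 `COc1ccc(C(=O)/C(=C/C2CCCCC2)CN(C)C(=O)c2ccccc2)cc1` has not yet been measured. It differs from compound 3 by cyclohexyl in place of 2,4-dichlorophenyl on a double-bonded chain carbon bound to a double-bonded chain carbon, which is the same change as that made from compound 1 to compound 2, at the same place. Because that earlier step was a 1.1-fold lower number from compound 1 to compound 2 (0.04 log units; within the scatter), the expected step from compound 3 to compound 4 is about a 1.1-fold lower number from compound 3 to compound 4 (0.04 log units; within the scatter). On that basis compound 4 is estimated to give 22000 nM in this assay, with a likely range from 11000 nM to 48000 nM.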

Compound 4, half-maximal inhibitory concentration: 39700 nM
Compound 4: the middle estimate sits 1.8-fold (0.26 log units) below what was measured; the measured number falls inside the stated range.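

In this assay, putting cyclohexyl in place of 2,4-dichlorophenyl gives a 1.7-fold higher number from compound 3 to compound 4 (0.22 log units; within the scatter), so on this core too the change makes no difference that can be told from the normal spread of repeated measurements. Going by these compounds alone, this does not show that the change is without any effect or that it would behave the same way on every core, only that these two cores give no sign of handling it differently. Side by side, the two steps cannot be told apart: the same change on two cores in this assay, a 1.1-fold lower number (0.04 log units; within the scatter) from compound 1 to compound 2 and a 1.7-fold higher number (0.22 log units; within the scatter) from compound 3 to compound 4, 1.8-fold (0.26 log units) apart, within the scatter of two such steps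

The compounds shown leave open what other groups at that place would do, such as an unsubstituted phenyl, a phenyl carrying an amine or a carboxylic acid, or a simple straight carbon chain. They also leave open whether the swap would hold on a core with a longer chain in place of the 1-acetoxyethyl or benzoyl(methyl)amino group.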